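A few compounds are considered here, and "the series" means these few. Any claim that something is new, unique, unknown or untested is made for them only; others in the source may bear on it.

Measured compounds in a functional assay on HeLa cells (Homo sapiens) for cytotoxicity, read by MTT assay, with a stated time of 48 h; on this read-out higher numbers stand for weaker inhibition and lower numbers for stronger inhibition:
- compound 1, `CC(C)c1cccc(OC(=O)c2cn(-c3ccccc3)nc2-c2cccnc2)c1`: > 100000 nM, a limit of the assay, not a number.
- compound 2, `CC(C)(C)c1ccc(OC(=O)c2cn(-c3ccccc3)nc2-c2cccnc2)cc1`: > 100000 nM, likewise a limit of the assay.
- compound 3, `O=C(Oc1ccc(-c2ccccc2)cc1)c1cn(-c2ccccc2)nc1-c1cccnc1`: > 100000 nM, again a limit of the assay.

Compound 2 therefore stands only at a limit, and the same is true of the two other values shown (the limit of > 100000 nM in this assay, at which 3 of the 3 values shown sit). The two measured steps, a step that the two limits leave unreadable from compound 1 to compound 2 and a step that the two limits leave unreadable from compound 2 to compound 3, cannot be read in size or direction, as both ends sit at the limit.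

Compound 4, `CC(C)(C)c1ccc(OC(=O)c2cn(-c3ccccc3)nc2-c2ccncc2)cc1`, differs from compound 2 by pyridin-4-yl in place of pyridin-3-yl on an aromatic carbon. Going by the values given here, no measured step bears on this change, and nothing in the set points away from the limit. Compound 4 is expected to remain at the limit, with an estimated step that the limit leaves unreadable from compound 2 to compound 4 in this assay. The estimate for compound 4 is 150000 nM, within 50000 nM to 500000 nM.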

Compound 4, half-maximal inhibitory concentration: 35400 nM
Estimate against measurement, compound 4: 4.2-fold (0.63 log units) above; the measured number lies below the stated range.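

In this assay, pyridin-4-yl in place of pyridin-3-yl on this aromatic carbon gives an at least 2.8-fold lower number from compound 2 to compound 4 (0.45 log units; beyond the scatter), so a change at this position can bring a compound of the series off the limit. Compound 2, at > 100000 nM, stands at a limit of the assay, not a number. The earlier steps, which changed the group on the oxygen, cannot be read: the limit of > 100000 nM in this assay, at which 3 of the 4 values shown sit.

Going by these compounds, whether pyridin-4-yl has the same outcome with the groups of compound 1 or compound 3 stays open. So does the outcome with a pyridin-2-yl or plain phenyl group on this carbon.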